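Furan-2-yl to furan-3-yl in a series at its limit

The source may report more compounds than this note shows. Statements on the series, on what has been measured and on what is new or still open speak of the compounds shown alone.

Compound 1 `Nc1nc(N)c2c(-c3ccco3)cn([C@@H]3O[C@H](CO)[C@@H](O)[C@H]3O)c2n1`: > 20000 nM
Compound 2 `COc1nc(N)nc2c1c(-c1ccco1)cn2[C@@H]1O[C@H](CO)[C@@H](O)[C@H]1O`: > 20000 nM

Both entries come from a functional assay on HCT-116 cells (Homo sapiens), read by MTT assay, with a stated time of 72 h (on this read-out lower numbers stand for stronger inhibition and higher numbers for weaker inhibition), and each is a limit of the assay, not a number. Compound 2 stands at > 20000 nM, which is a limit. Within the data shown here, the series so far shows only (the limit of > 20000 nM in this assay, at which 2 of the 2 values shown sit), so no compound can be ranked against another.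

Compound 3 `COc1nc(N)nc2c1c(-c1ccoc1)cn2[C@@H]1O[C@H](CO)[C@@H](O)[C@H]1O` differs from compound 2 as follows: furan-3-yl in place of furan-2-yl on an aromatic carbon. Among the measured compounds shown here, the only measured step is a step that the two limits leave unreadable from compound 1 to compound 2. That step concerns methoxy in place of amino, not the furan, and it gives no size to carry over. For the measured compounds named here, no measured step therefore bears directly on the furan change, and the only guide is the limit reached by compound 1 and compound 2.

No change beyond the usual scatter is expected in this assay, and a further limit is the most likely outcome. The expected step is a number no higher from compound 2 to compound 3 (the limit leaves the size open). For compound 3 the estimate is 20000 nM, with an expected range of 7000 nM to 40000 nM.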

Compound 3, half-maximal inhibitory concentration: > 20000 nM
Compound 3 was reported as a limit; the forecaster's own chance of this, stated with the estimate: 75%; the middle value sits exactly at the limit.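

In this assay compound 3 gives > 20000 nM, which is a limit and not a number. With compound 2 also reported as a limit, the step between compound 2 and compound 3 cannot be read. The series rests at a single limit: the limit of > 20000 nM in this assay, at which 3 of the 3 values shown sit.

The compounds shown leave open how furan-2-yl and furan-3-yl rank, and what place on the shared core, if any, gives a readable value in this assay.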